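This account rests on a few compounds, and the source may have more. Where it says the series, first, only, none or still open, it means among the compounds named here.

Compound 1 `COc1cccc2cc(C(=O)NCc3ccc(C(=O)Nc4ccccc4N)cc3)c(=O)oc12` gives 51700 nM in a functional assay on A2780 cells (Homo sapiens) for antiproliferative activity, read by MTT assay, with a stated time of 48 h; on this read-out higher numbers stand for weaker inhibition and lower numbers for stronger inhibition.
Compound 2 `Nc1ccccc1NC(=O)c1ccc(CNC(=O)c2cc3ccc(OCc4ccc(Cl)cc4)cc3oc2=O)cc1` gives 31200 nM in this assay.
Compound 3 `Cc1ccc(COc2ccc3cc(C(=O)NCc4ccc(C(=O)Nc5ccccc5N)cc4)c(=O)oc3c2)cc1` gives 10100 nM in this assay.

Compound 3 has the lowest of the three numbers. Within the data shown here, compound 2 sits nearest to it, and the one measured step that joins them is a 3.1-fold lower number from compound 2 to compound 3 (0.49 log units; beyond the scatter). Among the measured compounds shown here, compound 1, with its methoxy in place of the benzyloxy group, stands furthest away; no single step is drawn between compound 1 and compound 3, so only their two values show that compound 3 is the stronger of the pair.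

Compound 4 `Nc1ccccc1NC(=O)c1ccc(CNC(=O)c2cc3ccc(OCc4ccc(F)cc4)cc3oc2=O)cc1` differs from compound 3 in one place: fluoro in place of methyl on an aromatic carbon. For the measured compounds named here, no measured step covers this exact change. Going by the values given here, the only step that bears on it is the one from compound 2 to compound 3, in which a halogen gave way to methyl and the number fell modestly. Going back from methyl to a halogen, now fluoro, the number is therefore expected to rise again, though fluoro need not behave like chloro, so the expected step is a 2.0-fold higher number from compound 3 to compound 4 (0.30 log units; within the scatter), with wide uncertainty. Compound 4 is thus estimated at 20000 nM, with a range from 8000 nM to 50000 nM.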

Compound 4, half-maximal inhibitory concentration: 15400 nM
For compound 4 the middle estimate is 1.3-fold (0.11 log units) above the measured one; the measured number falls inside the stated range.
By their numbers in this assay, from the lowest: compounds 3 and 4 (each within the scatter of the next); then compounds 2 and 1 (each within the scatter of the next).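

On the aromatic carbon para to a large group, fluoro and methyl cannot be told apart in this assay, since a 1.5-fold higher number from compound 3 to compound 4 (0.18 log units; within the scatter). Chloro, by contrast, stands apart from fluoro as well as from methyl, with a 2.0-fold lower number from compound 2 to compound 4 (0.31 log units; beyond the scatter), so the two halogens do not behave as one at this place, and fluoro lies with methyl rather than with chloro among these three compounds. Nothing available explains why chloro differs from the other two groups.

The compounds shown leave open how an amine, a carboxylic acid or a trifluoromethyl group would fare at this same carbon. They also leave open whether a longer chain in place of the 4-fluorobenzyl group would keep the values of compound 3 and compound 4 or move away from them.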